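Aryl to aryloxy exchange on the shared core

A few compounds are considered here, and "the series" means these few. Any claim that something is new, unique, unknown or untested is made for them only; others in the source may bear on it.

Measured in a physicochemical assay for acid dissociation:
compound 1 `c1ccc(CCc2ccc3c(NCCCNCc4ccco4)ccnc3c2)cc1`: 9.47
compound 2 `Fc1ccc(Oc2ccc3c(NCCCNCc4ccco4)ccnc3c2)cc1`: 9.28
compound 3 `COc1ccc(-c2ccc3c(NCCCNCc4ccco4)ccnc3c2)cc1`: 9.47

Compound 3 and compound 1 stand together at the top of the three numbers; the step of no change at the digits printed from compound 1 to compound 3 (within the scatter) shows no separation, and the step of a number 0.19 log units higher from compound 2 to compound 3 (within the scatter) is small as well. Compound 4 `COc1ccc(Oc2ccc3c(NCCCNCc4ccco4)ccnc3c2)cc1` arises from compound 3 by the change (4-methoxyphenoxy in place of 4-methoxyphenyl on an aromatic carbon). Within the data shown here, two measured steps bear on this exchange. The step of a number 0.19 log units lower from compound 1 to compound 2 (within the scatter) put an aryl ether in place of a two-carbon link to a phenyl ring, and the step of a number 0.19 log units higher from compound 2 to compound 3 (within the scatter) went back from an aryl ether to a directly joined aryl ring; neither moved the number beyond the scatter. Compound 4 now takes the aryl ether with the methoxy group kept, so in this assay a step of a number 0.12 log units lower from compound 3 to compound 4 (within the scatter) is expected, at most a slight move downward and not a clear change. Compound 4 is therefore estimated at 9.35, within 9.1 to 9.6.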

Compound 4, acid dissociation constant: 9.28
Compound 4: the middle estimate sits 0.07 log units above what was measured; measured number inside the range.
By their numbers in this assay, from the lowest: compounds 2, 4, 1 and 3 (each within the scatter of the next).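

In this assay, among these compounds, 4-methoxyphenoxy in place of 4-methoxyphenyl gives a number 0.19 log units lower from compound 3 to compound 4 (within the scatter) and so isolates the exchange of a directly joined aryl ring for an aryl ether with the methoxy group held constant, a comparison the earlier compounds did not offer. Methoxy in place of fluoro gives no change at the digits printed from compound 2 to compound 4 (within the scatter) and 4-methoxyphenoxy in place of phenethyl gives a number 0.19 log units lower from compound 1 to compound 4 (within the scatter), so neither the link nor the substituent on the outer ring separates the four compounds at this position. Nothing available gives a reason for these numbers or ties them to a feature of any group.

As far as these compounds go, all four compounds carry a carbon-only aromatic ring on this position, so the reading with a carboxylic acid or a morpholine there remains open. Also open, from the compounds shown here alone, is whether a longer chain elsewhere on the shared core would shift the number beyond the scatter.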